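The source may report more compounds than this note shows. Statements on the series, on what has been measured and on what is new or still open speak of the compounds shown alone.

Three compounds share one core and differ only in the group on the ring nitrogen. Compound 1 `CN(C)c1ccc(C2CC(c3ccc(-n4ccnc4)cc3)=NN2C(=O)CCCl)cc1` gives 2.1% in a functional assay on MDA-MB-231 cells (Homo sapiens) for inhibition, read by sulforhodamine B assay, tested at 10 uM; a lower number here means less inhibition, a higher number more inhibition at the concentration tested (going by the name of the read-out). Compound 2 `C=C(C)C(=O)N1N=C(c2ccc(-n3ccnc3)cc2)CC1c1ccc(N(C)C)cc1` gives 4.3% in this assay, and compound 3 `CN(C)c1ccc(C2CC(c3ccc(-n4ccnc4)cc3)=NN2C(=O)c2ccc(F)cc2)cc1` gives 9.4% in this assay. Compound 3 holds the highest of the three numbers, yet the steps of a number 7.3 percentage points higher from compound 1 to compound 3 (within the scatter) and a number 5.1 percentage points higher from compound 2 to compound 3 (within the scatter) both sit within the scatter, so the three cannot be told apart. Compound 4 `CN(C)c1ccc(C2CC(c3ccc(-n4ccnc4)cc3)=NN2S(=O)(=O)c2ccc(C#N)cc2)cc1` carries (4-cyanophenyl)sulfonyl in place of (4-fluorophenyl)carbonyl on an amine nitrogen in a ring. Among the measured compounds shown here, no measured step swaps a carbonyl for a sulfonyl; the steps measured, including a number 2.2 percentage points higher from compound 1 to compound 2 (within the scatter), each changed only the group on the carbonyl carbon and all stayed within the scatter. No step beyond the scatter is therefore expected in this assay, and a number 0.6 percentage points higher from compound 3 to compound 4 (within the scatter) is the estimated step. Compound 4 is expected to give 10%, between 0% and 25%.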

Compound 4, a percentage reported as inhibition, at one concentration (the size of the read-out at that concentration, not a potency): 7.1%
Estimate against measurement, compound 4: 2.9 percentage points above; the range from low to high includes it.
By their numbers in this assay, from the lowest: compounds 1, 2, 4 and 3 (each within the scatter of the next).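

Among the compounds shown here, compound 4 is the first here to replace the carbonyl with a sulfonyl on the amine nitrogen in a ring, and it also brings a nitrile on the phenyl ring. In this assay this gives a number 2.3 percentage points lower from compound 3 to compound 4 (within the scatter), along with a number 2.8 percentage points higher from compound 2 to compound 4 (within the scatter) and a number 5 percentage points higher from compound 1 to compound 4 (within the scatter), so all the sulfonyl and carbonyl compounds shown remain indistinguishable. Nothing available explains these numbers.

On these data alone, the linker and the nitrile changed together, so their separate contributions stay unknown. As far as these compounds go, it also remains open whether an amine, a carboxylic acid or a longer chain at this position would give a step beyond the scatter.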